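A few compounds are considered here, and "the series" means these few. Any claim that something is new, unique, unknown or untested is made for them only; others in the source may bear on it.

Measured so far:
compound 1, `O=C1C(Nc2ccc(F)cc2)=CC(=O)c2ncccc21`, 79%
compound 2, `O=C1C(Nc2cccc(F)c2)=CC(=O)c2ncccc21`, 85%

Both compounds were tested in a functional assay on the whole organism (aorta) with Rattus norvegicus as the target; on this read-out higher numbers stand for larger maximal responses and lower numbers for smaller maximal responses. In this assay compound 1 gives 79% and compound 2 gives 85%. The two numbers lie within the usual scatter of each other, so they cannot be told apart: compound 2 is simply the nearer starting point for the next compound, not a stronger one.

Compound 3, `O=C1C(Nc2ccc(F)c(F)c2)=CC(=O)c2ncccc21`, differs from compound 2 in one place: fluoro in place of hydrogen on an aromatic carbon. For the measured compounds named here, no pair of measured compounds shows what such an added fluoro does in this assay, so there is nothing to lean on but the fact that a single small group enters while the shared core and the rest of the aniline part remain. A step of this kind is expected to move the largest response in this assay little, in neither direction beyond the scatter.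

The estimated step from compound 2 to compound 3 is therefore a number 1 percentage points lower from compound 2 to compound 3 (within the scatter). Compound 3 is expected to reach about 84% in this assay, with a range from 70% to 96%.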

Compound 3, largest response reached (Emax), in percent of the reference or control that the assay uses: 92%
For compound 3 the middle estimate is 8 percentage points below the measured one; the range from low to high includes it.
By their numbers in this assay, from the lowest: compounds 1, 2 and 3 (each within the scatter of the next, the first and the last beyond it).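

In this assay, fluoro in place of hydrogen on an aromatic carbon, ortho to a fluoro group and para to a large group, gives a number 7 percentage points higher from compound 2 to compound 3 (within the scatter), so at this position the added fluoro cannot be told apart from no change. Compound 3 also carries a fluoro group in place of a hydrogen of compound 1, and that change gives a number 13 percentage points higher from compound 1 to compound 3 (beyond the scatter), a modest step but the first in this set to rise clearly above the scatter, showing that a single added fluoro can matter on this aniline part when it is made on compound 1. Nothing measured here accounts for either step, or for why the two differ in whether they can be read.

The compounds shown leave open whether a chloro, a methoxy or an amine group on this same carbon would give a similar response. They also leave open how a ring with hydrogen in place of both fluoro groups would compare with compound 1, compound 2 and compound 3.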